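This account rests on a few compounds, and the source may have more. Where it says the series, first, only, none or still open, it means among the compounds named here.

Compound 1, `CCOC(=O)C1(Cc2ccccc2)CN(c2ccccc2)Cc2nnn(Cc3cccc(Cl)c3)c21`: in an ADME assay on HEL cells (Homo sapiens) for cytotoxicity, read by microscopy, with a stated time of 3 days (on this read-out lower numbers stand for higher toxicity in this test and higher numbers for lower toxicity in this test), compound 1 gives > 100000 nM, which is a limit of the assay and not a number.
Compound 2, `c1ccc(N2CCc3c(nnn3CC3CC3)C2)cc1`: in this assay compound 2 gives > 100000 nM, again a limit of the assay.
Compound 3, `CCCCCCn1nnc2c1CCN(c1ccccc1)C2`: in this assay compound 3 gives > 100000 nM, also a limit of the assay.

Compound 3 therefore stands only at a limit in this assay, and the two other values shown sit at the same limit (the limit of > 100000 nM in this assay, at which 3 of the 3 values shown sit). For the measured compounds named here, the one step that joins two measured compounds, a step that the two limits leave unreadable from compound 2 to compound 3, cannot be read as a size, since both ends are limits.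

Compound 4, `CCCCCCn1nnc2c1CCN(c1ccc(F)cc1)C2`, differs from compound 3 by fluoro in place of hydrogen on an aromatic carbon. Going by the values given here, no measured step bears on a change of this kind, and the step from compound 2 to compound 3 gives no size to build on. With every value shown sitting at the limit, the expectation for compound 4 in this assay is no step beyond the scatter, so that compound 4 is estimated at 100000 nM, within 50000 nM to 200000 nM. The step this estimate means, a number no higher from compound 3 to compound 4 (the limit leaves the size open), is expected to be nil, and a further limit rather than a number is the likelier outcome.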

Compound 4, minimum cytotoxic concentration: > 100000 nM
Compound 4: a limit, no number (the forecaster's own chance of this, stated with the estimate: 85%); the middle value sits exactly at the limit.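

No step can be read between compound 3 and compound 4, since both values are limits of the assay and not numbers: the limit of > 100000 nM in this assay, at which 4 of the 4 values shown sit.

The compounds shown leave open which change to the shared core, if any, would give a measured number in this assay.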